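Substituent change on the aryl ring of compound 3

This account rests on a few compounds, and the source may have more. Where it says the series, first, only, none or still open, it means among the compounds named here.

The measured compounds and their numbers in a functional assay on HepG2 cells (Homo sapiens) for inhibition, read by MTT assay, with a stated time of 72 h; a higher number here means a weaker inhibitor, a lower number a stronger inhibitor:
compound 1, `Cc1cccc(-n2cc(COc3cccc(NC(=O)Nc4ccc(Cl)c(C(F)(F)F)c4)c3)nn2)c1`, gives 7270 nM
compound 2, `CC(C)c1cccc(-n2cc(COc3cccc(NC(=O)Nc4ccc(Cl)c(C(F)(F)F)c4)c3)nn2)c1`, gives 3250 nM
compound 3, `O=C(Nc1cccc(OCc2cn(-c3cccc(Br)c3)nn2)c1)Nc1ccc(Cl)c(C(F)(F)F)c1`, gives 1040 nM

Compound 3 stands lowest of the three in this assay. Its nearest neighbour is compound 2, and the change is a 3.1-fold lower number from compound 2 to compound 3 (0.49 log units; beyond the scatter). The gap to compound 1 is wider: a 7.0-fold lower number from compound 1 to compound 3 (0.84 log units; beyond the scatter). The step between the two other compounds, a 2.2-fold lower number from compound 1 to compound 2 (0.35 log units; beyond the scatter), is the smallest of the three.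

Compound 4, `O=C(Nc1cccc(OCc2cn(-c3ccc(C(F)(F)F)cc3)nn2)c1)Nc1ccc(Cl)c(C(F)(F)F)c1`, has not yet been measured. It differs from compound 3 in one place: 4-(trifluoromethyl)phenyl in place of 3-bromophenyl on an aromatic nitrogen. Going by the values given here, none of the measured steps carries this exact change. Among the compounds with values here, the steps that bear on it are those that alter the same ring, and all three exchange one group for another on an aromatic carbon, whereas here both the group and its position on the ring change at once. Those steps were of modest size in either direction, so a step of similar size, in either direction, is expected here, with no strong lean.

Compound 4 is therefore expected to give 1600 nM, in a range from 500 nM to 5000 nM, which would mean an expected step of a 1.5-fold higher number from compound 3 to compound 4 (0.19 log units; within the scatter).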

Compound 4, half-maximal inhibitory concentration: 1800 nM
The estimate for compound 4 lay 1.1-fold (0.05 log units) below the measured number; measured number inside the range.
By their numbers in this assay, from the lowest: compounds 3, 4 and 2 (each within the scatter of the next, the first and the last beyond it); then compound 1.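

In this assay, 4-(trifluoromethyl)phenyl on the aromatic nitrogen reads the same as the 3-bromophenyl within the scatter (a 1.7-fold higher number from compound 3 to compound 4 (0.24 log units; within the scatter)), and the same holds against the 3-isopropylphenyl (a 1.8-fold lower number from compound 2 to compound 4 (0.26 log units; within the scatter)), while only the comparison with the 3-methylphenyl clears the scatter (a 4.0-fold lower number from compound 1 to compound 4 (0.61 log units; beyond the scatter)). The earlier compounds shown here changed only the group on the ring, whereas this one shows that changing the group and its place together need not move the number beyond the scatter, and that the 3-methylphenyl of compound 1 remains the one clearly set apart from the other three. Nothing at hand gives a reason for this result.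

The compounds shown cannot separate the effect of the group from the effect of its place on the ring, as neither bromo nor trifluoromethyl appears here at both places. They also leave open how this phenyl ring would read in this assay if it carried an amine, a carboxylic acid or a longer alkyl chain, or if a group were placed on it at a third position.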